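The source may report more compounds than this note shows. Statements on the series, on what has been measured and on what is new or still open speak of the compounds shown alone.

Compound 3, `O=c1nc2oc(C3CC3)cc2cn1Cc1cn(-c2ccc(Cl)cc2)nn1`, carries a 4-chlorophenyl group on the triazole nitrogen of the shared core. In a functional assay on SW-620 cells (Homo sapiens) for antiproliferative activity, read by MTT assay, with a stated time of 72 h (a lower number here means a stronger inhibitor, a higher number a weaker inhibitor), compound 3 reaches only the limit of the assay and gives > 100000 nM. Among the values shown this is the limit of > 100000 nM in this assay, at which 1 of the 3 values shown sits, so compound 3 is known only as weaker than that bound and cannot be placed more exactly.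

Compound 4, `O=c1nc2oc(C3CC3)cc2cn1Cc1cn(Cc2ccccc2)nn1`, differs from compound 3 in one place: benzyl in place of 4-chlorophenyl on an aromatic nitrogen. The two benzyl compounds that have been measured in this assay hold the same triazole-linked group. Compound 1, `O=c1nc2oc(C3CC3)c(C#CC3CC3)c2cn1Cc1cn(Cc2ccccc2)nn1`, gives 9720 nM in this assay, and compound 2, `O=c1nc2oc(CCCCl)cc2cn1Cc1cn(Cc2ccccc2)nn1`, gives 75500 nM. Both of them have numbers rather than limits, which sets them apart from compound 3. Compound 4 shares the cyclopropyl substituent on its oxygen-bearing ring with compound 1 but lacks the cyclopropylethynyl group, and it lacks the chlorobutyl chain of compound 2.

Because compound 1 gives 9720 nM with the benzyl group in place, compound 4 is expected to come in at 40000 nM, with a range from 10000 nM to 100000 nM. The step of an at least 2.5-fold lower number from compound 3 to compound 4 (0.39 log units; beyond the scatter) is therefore expected to run toward a lower number, beyond the usual scatter, though a further limit cannot be ruled out.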

Compound 4, half-maximal inhibitory concentration: 54700 nM
The estimate for compound 4 lay 1.4-fold (0.14 log units) below the measured number; low and high end bracket the measured number.
By their numbers in this assay, from the lowest: compound 1; then compounds 4 and 2 (each within the scatter of the next). At a limit, above all of these: compound 3.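

In this assay, benzyl in place of 4-chlorophenyl on the aromatic nitrogen gives the only step shown at this position, an at least 1.8-fold lower number from compound 3 to compound 4 (0.26 log units; that floor lies within the scatter), so a real gain from this swap is not established, and the reading rests on a limit held by compound 3: the limit of > 100000 nM in this assay, at which 1 of the 4 values shown sits. With benzyl held on that nitrogen, cyclopropyl in place of 3-chloropropyl on an aromatic carbon gives a 1.4-fold lower number from compound 2 to compound 4 (0.14 log units; within the scatter), so these two compounds cannot be told apart. Hydrogen in place of 2-cyclopropylethynyl on an aromatic carbon gives a 5.6-fold higher number from compound 1 to compound 4 (0.75 log units; beyond the scatter), the only new step that is printed as clearing the scatter.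

Benzyl and 4-chlorophenyl differ both in the chlorine and in one added carbon, and the compounds shown do not separate these two differences, which leaves open how a plain phenyl or a 4-chlorobenzyl group on that nitrogen would read. Also open, going by these compounds, is whether an amine or a carboxylic acid on the benzyl ring would shift the number beyond the scatter.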